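Terminal alkyne in place of the propargyl alcohol

The source may hold more compounds than are shown below. What is called first, only, known or untested is meant among the compounds shown, and "the series" means these compounds.

Measured compounds:
compound 1 `Cc1nc(C#Cc2cncc(Br)c2)cs1` — 60 nM
compound 2 `Cc1nc(C#Cc2cncc(C#CCO)c2)cs1` — 68.6 nM

Compound 2 carries the highest of the two numbers in a functional assay on CHO cells for agonist activity at metabotropic glutamate receptor 5 (Homo sapiens), read by inositol phosphate accumulation (on this read-out higher numbers stand for weaker inhibition and lower numbers for stronger inhibition), and in this assay compound 2 gives 68.6 nM, with compound 1 as its nearest neighbour; the gap a 1.1-fold higher number from compound 1 to compound 2 (0.06 log units; within the scatter) lies within the scatter. Compound 3 `C#Cc1cncc(C#Cc2csc(C)n2)c1` has not been measured. It differs from compound 2 by hydrogen in place of hydroxymethyl on a triple-bonded carbon. For the measured compounds named here, the only measured step that touches this part of the molecule is a 1.1-fold higher number from compound 1 to compound 2 (0.06 log units; within the scatter), which is small, and no step alters an alkyne substituent itself. Because a 1.1-fold higher number from compound 1 to compound 2 (0.06 log units; within the scatter) showed no shift, a further change at the same aromatic carbon is expected to produce no step beyond the scatter, with the direction left open. Compound 3 is therefore estimated at 60 nM, within 25 nM to 150 nM, a step of a 1.1-fold lower number from compound 2 to compound 3 (0.06 log units; within the scatter) that is expected to stay within the scatter.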

Compound 3, half-maximal inhibitory concentration: 19.2 nM
The estimate for compound 3 lay 3.1-fold (0.49 log units) above the measured number; measured number outside the range, below it.
By their numbers in this assay, from the lowest: compound 3; then compounds 1 and 2 (each within the scatter of the next).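

In this assay, the aromatic carbon proves less indifferent to its substituent than the earlier pair suggested: hydrogen in place of hydroxymethyl on a triple-bonded carbon gives a 3.6-fold lower number from compound 2 to compound 3 (0.55 log units; beyond the scatter), and ethynyl in place of bromo on an aromatic carbon gives a 3.1-fold lower number from compound 1 to compound 3 (0.49 log units; beyond the scatter). Bromo and 3-hydroxyprop-1-yn-1-yl had stood within the scatter of each other, but that match does not extend to ethynyl, and an alkyne at this carbon does not by itself set the number, since the two alkynes differ beyond the scatter. Nothing in the data accounts for this step.

Left open is whether a methyl group on the triple-bonded carbon would read like hydrogen or like hydroxymethyl, which would separate the carbon from the hydroxyl. From the compounds shown here alone, an amine in place of that hydroxyl, or a longer chain on the alkyne, is equally open.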